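Para Substituents on the Phenyl of Compound 2's Core

A few compounds are considered here, and "the series" means these few. Any claim that something is new, unique, unknown or untested is made for them only; others in the source may bear on it.

Compound 1, `Cn1cc(/C=C2/C(=O)Nc3ccccc32)c2cc(Nc3nccc(-c4ccccc4)n3)ccc21`, gives 13400 nM in a functional assay on LNCaP cells (Homo sapiens) for cytotoxicity, read by MTT assay, with a stated time of 48 h; a lower number here means a stronger inhibitor, a higher number a weaker inhibitor. Compound 2, `Cn1cc(/C=C2/C(=O)Nc3ccccc32)c2cc(Nc3nccc(-c4ccc(O)cc4)n3)ccc21`, gives 10800 nM. Compound 3, `Cn1cc(/C=C2/C(=O)Nc3ccccc32)c2cc(Nc3nccc(-c4ccc(Cl)cc4)n3)ccc21`, gives 6590 nM.

Compound 2 sits second highest of the three numbers; its nearest neighbour is compound 1, a 1.2-fold lower number from compound 1 to compound 2 (0.09 log units; within the scatter), and its furthest is compound 3, a 1.6-fold lower number from compound 2 to compound 3 (0.21 log units; within the scatter). Compound 4, `Cn1cc(/C=C2/C(=O)Nc3ccccc32)c2cc(Nc3nccc(-c4ccc(C(F)(F)F)cc4)n3)ccc21`, differs from compound 2 in one place: trifluoromethyl in place of hydroxy on an aromatic carbon. The step that bears most directly on it is a 1.6-fold lower number from compound 2 to compound 3 (0.21 log units; within the scatter), where another group took the place of the same hydroxy; the move from hydrogen to chloro, a 2.0-fold lower number from compound 1 to compound 3 (0.31 log units; beyond the scatter), points the same way. A modest lowering is therefore expected, a 1.7-fold lower number from compound 2 to compound 4 (0.22 log units; within the scatter). For compound 4 the estimate in this assay is 6500 nM, with a range from 3000 nM to 15000 nM.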

Compound 4, half-maximal inhibitory concentration: > 100000 nM
Compound 4: only a limit was reported; the forecaster's own chance of this, stated with the estimate: 5%; middle value at least 15-fold (1.18 log units) away from the limit.
By their numbers in this assay, from the lowest: compounds 3, 2 and 1 (each within the scatter of the next, the first and the last beyond it). At a limit, above all of these: compound 4.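

Compound 4 gives only a limit in this assay, not a number: the limit of > 100000 nM in this assay, at which 1 of the 4 values shown sits. Trifluoromethyl brings an at least 9.2-fold higher number from compound 2 to compound 4 (0.96 log units; beyond the scatter), an at least 15-fold higher number from compound 3 to compound 4 (1.18 log units; beyond the scatter) and an at least 7.4-fold higher number from compound 1 to compound 4 (0.87 log units; beyond the scatter), each beyond the scatter, so this place, where hydrogen, hydroxy and chloro kept the numbers in one range, does not accept every group. The lowering seen with chloro does not carry over to trifluoromethyl.

What separates these two groups cannot be told from the compounds shown. On these data alone, it also remains open whether a methoxy group, an amine or a carboxylic acid here would behave like chloro or like trifluoromethyl.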